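This account rests on a few compounds, and the source may have more. Where it says the series, first, only, none or still open, it means among the compounds named here.

Compound 1 `COc1nsnc1C(=O)Nc1cc(C(F)(F)F)cc(C(F)(F)F)c1` stands highest of the two numbers in hand: in an assay on isolated protein for inhibition of mitogen-activated protein kinase kinase kinase 14 (Homo sapiens), read by ADP-Glo, with a stated time of 60 min, tested at 100 uM, in the presence of a further agent that is not named here (a higher number here means more inhibition at the concentration tested (going by the name of the read-out), a lower number less inhibition), compound 1 gives -1.9%. Its nearest neighbour is compound 2 `Nc1nonc1C(=O)Nc1cc(C(F)(F)F)cc(C(F)(F)F)c1`, which in this assay gives -9.2%, the step of a number 7.3 percentage points lower from compound 1 to compound 2 (within the scatter) lying within the scatter. Compound 3 `O=C(Nc1cc(C(F)(F)F)cc(C(F)(F)F)c1)c1nonc1O` differs from compound 1 in one place: a group of 6 heavy atoms (2 carbon, 2 nitrogen, 2 oxygen; one five-membered aromatic ring with 3 hetero atoms) in place of a group of 7 heavy atoms (3 carbon, 2 nitrogen, 1 oxygen, 1 sulfur; one five-membered aromatic ring with 3 hetero atoms), on a carbonyl carbon. Going by the values given here, the only measured step that bears on this change is the one from compound 1 to compound 2, which was within the scatter, so no change beyond the scatter is expected for a number 2.1 percentage points lower from compound 1 to compound 3 (within the scatter). Compound 3 is therefore estimated to give -4%, expected between -15% and 8%.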

Compound 3, a percentage reported as inhibition, at one concentration (the size of the read-out at that concentration, not a potency): 19.3%
Beside the measured number, compound 3's estimate is 23.3 percentage points below it, outside the stated range (above it).
By their numbers in this assay, from the lowest: compounds 2 and 1 (each within the scatter of the next); then compound 3.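

Placing 4-hydroxy-1,2,5-oxadiazol-3-yl on the carbonyl carbon gives a number 21.2 percentage points higher from compound 1 to compound 3 (beyond the scatter) in this assay and thus moves the read-out beyond the scatter for the first time in this series. Hydroxy in place of amino on an aromatic carbon gives a number 28.5 percentage points higher from compound 2 to compound 3 (beyond the scatter) and shows that this single exchange on the ring is enough to separate the two compounds. Nothing available here explains this difference. Still open, from the compounds shown here alone, is whether a carboxylic acid or a methyl group in place of the hydroxy would keep, lose or extend this gain.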